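The source may hold more compounds than are shown below. What is called first, only, known or untested is meant among the compounds shown, and "the series" means these compounds.

Measured so far in an assay on membranes from brain for displacement of a labelled ligand from Sigma non-opioid intracellular receptor 1 (Cavia porcellus); on this read-out higher numbers stand for weaker inhibition and lower numbers for stronger inhibition:
compound 1 `COC1Cc2sccc2C2(CCN(CCCc3ccccc3)CC2)O1` gives 2.4 nM;
compound 2 `COC1Cc2sccc2C2(CCN(CCCCc3ccccc3)CC2)O1` gives 7.7 nM;
compound 3 `CCCCN1CCC2(CC1)OC(OC)Cc1sccc12` gives 4.3 nM.

Compound 3 stands second highest of the three numbers, within the scatter of both compound 1 and compound 2. Compound 4 `CCCCCCCCN1CCC2(CC1)OC(OC)Cc1sccc12` carries butyl in place of hydrogen on a saturated chain carbon, four bonds along the chain from an amine nitrogen in a ring, an extension of the chain. Bearing on it are a 1.8-fold lower number from compound 2 to compound 3 (0.25 log units; within the scatter), a 1.8-fold higher number from compound 1 to compound 3 (0.25 log units; within the scatter) and a 3.2-fold higher number from compound 1 to compound 2 (0.51 log units; beyond the scatter). Only the benzyl-for-phenyl exchange moved this assay beyond the scatter; the other chain exchanges stayed within it. Further extension of the chain in compound 4 is therefore expected to shift this assay little, if at all, a 1.2-fold lower number from compound 3 to compound 4 (0.09 log units; within the scatter). Compound 4 is estimated at 3.5 nM, with a range from 1.2 nM to 11 nM.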

Compound 4, inhibition constant: 5.1 nM
Beside the measured number, compound 4's estimate is 1.5-fold (0.16 log units) below it, within the range that was stated.
By their numbers in this assay, from the lowest: compounds 1, 3, 4 and 2 (each within the scatter of the next, the first and the last beyond it).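

In this assay, butyl in place of hydrogen at this place, four bonds along the chain from the amine nitrogen in the ring, stays within the scatter: a 1.2-fold higher number from compound 3 to compound 4 (0.07 log units; within the scatter). Butyl in place of phenyl at the same place also stays within it: a 1.5-fold lower number from compound 2 to compound 4 (0.18 log units; within the scatter). Only pentyl in place of phenyl, three bonds along the chain, passes the scatter, and modestly: a 2.1-fold higher number from compound 1 to compound 4 (0.33 log units; beyond the scatter). No measurement at hand accounts for these steps.

Open, going by these compounds, is how this assay responds to a longer chain, or to a carboxylic acid or a hydroxyl on this chain.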